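Series notes: replacing the 2,6-dimethoxyphenyl group

The compounds below may be only part of what the source reports. "The series", "measured", "known", "first", "only" and "open" are said of these compounds alone.

In a functional assay on UO-31 cells (Homo sapiens) for inhibition, read by sulforhodamine B assay, with a stated time of 48 h (a lower number here means a stronger inhibitor of growth, a higher number a weaker inhibitor of growth), compound 1 `O=C(Cc1csc2nc(-c3ccc(Br)cc3)cn12)N/N=C/c1ccccc1O` gives 7080 nM, compound 2 `O=C(Cc1csc2nc(-c3ccc(Br)cc3)cn12)N/N=C/c1ccc(O)cc1` gives 26300 nM and compound 3 `COc1cccc(OC)c1/C=N/NC(=O)Cc1csc2nc(-c3ccc(Br)cc3)cn12` gives 60300 nM, the highest of the three numbers. Compound 4 `O=C(Cc1csc2nc(-c3ccc(Br)cc3)cn12)N/N=C/c1ccc(Cl)cc1Cl` carries 2,4-dichlorophenyl in place of 2,6-dimethoxyphenyl on a carbon with a double bond to nitrogen. For the measured compounds named here, no measured step makes this exact exchange. The closest evidence comes from changes at the same place: a 3.7-fold higher number from compound 1 to compound 2 (0.57 log units; beyond the scatter), an 8.5-fold higher number from compound 1 to compound 3 (0.93 log units; beyond the scatter) and a 2.3-fold higher number from compound 2 to compound 3 (0.36 log units; beyond the scatter), all modest but beyond the scatter. With compound 3 at the top of this range, a modest step to a lower number is expected in this assay. The expected step is a 3.0-fold lower number from compound 3 to compound 4 (0.48 log units; beyond the scatter). For compound 4 the estimate is 20000 nM, with an expected range of 6000 nM to 60000 nM.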

Compound 4, concentration for 50% growth inhibition: 72400 nM
Compound 4: the middle estimate sits 3.6-fold (0.56 log units) below what was measured; the whole stated range lies below it.
By their numbers in this assay, from the lowest: compound 1; then compound 2; then compounds 3 and 4 (each within the scatter of the next).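

In this assay, 2,4-dichlorophenyl and 2,6-dimethoxyphenyl on this carbon cannot be told apart (a 1.2-fold higher number from compound 3 to compound 4 (0.08 log units; within the scatter)), so two quite different substituent sets share the top of the range. For the compounds shown here, both hydroxyphenyl compounds give lower numbers (a 2.8-fold higher number from compound 2 to compound 4 (0.44 log units; beyond the scatter); a 10-fold higher number from compound 1 to compound 4 (1.01 log units; beyond the scatter)), and the latter is the first large step at this position, with no exception among the four compounds. No measurement available here accounts for these differences.

From the compounds shown here alone, it remains open whether an amine or a carboxylic acid in place of the hydroxyl would keep the lower numbers of compound 1 and compound 2.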